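The source may hold more compounds than are shown below. What is called first, only, known or untested is meant among the compounds shown, and "the series" means these compounds.

Within the data shown here, in a functional assay on PC-3 cells (Homo sapiens) for inhibition (a lower number here means a stronger inhibitor, a higher number a weaker inhibitor), compound 2 `Cc1c(C(=O)N/N=C\c2cccc(F)c2O)oc2cccc(O)c12` gives 12700 nM, the lowest of the three numbers so far. Compound 1 `Cc1c(C(=O)N/N=C\c2ccccc2C(F)(F)F)oc2cccc(O)c12` gives 26200 nM, and compound 3 `Cc1c(C(=O)N/N=C\c2cc(O)ccc2O)oc2cccc(O)c12` gives 95500 nM. Compound 4 `Cc1c(C(=O)N/N=C\c2ccc(O)cc2O)oc2cccc(O)c12` differs from compound 2 in one place: 2,4-dihydroxyphenyl in place of 3-fluoro-2-hydroxyphenyl on a carbon with a double bond to nitrogen. Among the measured compounds shown here, the one measured step that bears on this change is a 7.5-fold higher number from compound 2 to compound 3 (0.88 log units; beyond the scatter), in which a hydroxyl likewise replaced the fluorine on the same ring; that step was modest but beyond the scatter. Whether 2,4-dihydroxyphenyl behaves like 2,5-dihydroxyphenyl is not known from these compounds. The number in this assay is nevertheless expected to rise, by about a 3.9-fold higher number from compound 2 to compound 4 (0.60 log units; beyond the scatter). Compound 4 is therefore estimated at 50000 nM, with a range of 18000 nM to 140000 nM.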

Compound 4, half-maximal inhibitory concentration: 14800 nM
Compound 4: the middle estimate sits 3.4-fold (0.53 log units) above what was measured, outside the stated range (below it).
By their numbers in this assay, from the lowest: compounds 2, 4 and 1 (each within the scatter of the next, the first and the last beyond it); then compound 3.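

In this assay, 2,4-dihydroxyphenyl can stand in for 3-fluoro-2-hydroxyphenyl on the carbon with a double bond to nitrogen with no change beyond the scatter (a 1.2-fold higher number from compound 2 to compound 4 (0.07 log units; within the scatter)), so the rise seen with compound 3 does not extend to every dihydroxyphenyl group. The arrangement of the two hydroxyls matters here (a 6.5-fold lower number from compound 3 to compound 4 (0.81 log units; beyond the scatter)), with 2,4-dihydroxyphenyl matching the fluorinated ring and 2,5-dihydroxyphenyl not.

Going by these compounds, what an amine or a methoxy group would give in place of the second hydroxyl of 2,4-dihydroxyphenyl remains open. So does whether any group on this ring can bring the number well below that of compound 2.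

No measurement at hand accounts for the difference between the two dihydroxyphenyl groups.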